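Swapping bromo for fluoro in compound 2

A few compounds are considered here, and "the series" means these few. Any claim that something is new, unique, unknown or untested is made for them only; others in the source may bear on it.

In a functional assay on HL-60 cells (Homo sapiens) for inhibition, read by luminescence, with a stated time of 72 h, tested at 5 uM (a higher number here means more inhibition of growth at the concentration tested, a lower number less inhibition of growth), compound 2 (`C=CS(=O)(=O)NC/C=C/c1cc(OC)cc(O)c1C(=O)OCc1ccc(Br)cc1`) gives 8.1%. Compound 1 (`C=CS(=O)(=O)NC/C=C/c1cc(OC)cc(O)c1C(=O)OCC1CCCCC1`) gives 7.5%, so the two sit within the scatter of each other. Compound 3 (`COc1cc(O)c(C(=O)OC(C)C)c(/C=C/CN2C(=O)C=CC2=O)c1`) gives 65.7%, a far higher number, but its structure differs from theirs in more than one place, so it says little about the change considered here.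

Compound 4 (`C=CS(=O)(=O)NC/C=C/c1cc(OC)cc(O)c1C(=O)OCc1ccc(F)cc1`) differs from compound 2 at a single spot: fluoro in place of bromo on an aromatic carbon. It carries fluoro in place of bromo on an aromatic carbon, para to a large group.

Among the measured compounds shown here, no measured pair isolates this halogen exchange. The nearest evidence is a number 0.6 percentage points higher from compound 1 to compound 2 (within the scatter), where 4-bromophenyl replaced cyclohexyl and the number stayed within the scatter. A smaller change at the same group is therefore not expected to move the result beyond the scatter. The expected step is a number 0.1 percentage points lower from compound 2 to compound 4 (within the scatter). Compound 4 is estimated at 8%, with an expected range from 0% to 18%.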

Compound 4, percent growth inhibition at one concentration: 10.9%
For compound 4 the middle estimate is 2.9 percentage points below the measured one; the measured number falls inside the stated range.
By their numbers in this assay, from the lowest: compounds 1, 2 and 4 (each within the scatter of the next); then compound 3.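

Among the compounds shown here, this is the first pair in which only the halogen changes. In this assay, fluoro in place of bromo on an aromatic carbon, para to a large group, gives a number 2.8 percentage points higher from compound 2 to compound 4 (within the scatter), so exchanging these two halogens does not separate the compounds. Replacing cyclohexyl with 4-fluorophenyl gives a number 3.4 percentage points higher from compound 1 to compound 4 (within the scatter) and so also leaves the result unresolved, which means compounds 1, 2 and 4 all lie within the scatter of one another. No measurement shown here offers an explanation for these numbers.

On these data alone, it remains open whether an amine or a carboxylic acid on that aromatic carbon would give a different number. As far as these compounds go, compound 3 differs from these compounds in more than one place, so which of those differences goes with its far higher number also stays open.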